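This account rests on a few compounds, and the source may have more. Where it says the series, first, only, none or still open, it means among the compounds named here.

Among the compounds with values here, compound 2 `O=C(/C=C/c1cccc(NS(=O)(=O)c2cccc(Cl)c2)c1)c1nc2ccccc2[nH]1` gives 4160 nM in a functional assay on MCF7 cells (Homo sapiens) for antiproliferative activity, read by MTT assay, with a stated time of 48 h (on this read-out lower numbers stand for stronger inhibition and higher numbers for weaker inhibition), the lowest of the two numbers so far; compound 1 `O=C(Nc1cccc(/C=C/C(=O)c2nc3ccccc3[nH]2)c1)c1ccccc1` gives 11200 nM. Within the data shown here, the single measured step, a 2.7-fold lower number from compound 1 to compound 2 (0.43 log units; beyond the scatter), changed the group on the aromatic nitrogen, not the ring on the sulfonyl sulfur, so it says little about compound 3 `Cc1ccc(S(=O)(=O)Nc2cccc(/C=C/C(=O)c3nc4ccccc4[nH]3)c2)cc1C`, which differs from compound 2 by 3,4-dimethylphenyl in place of 3-chlorophenyl on a sulfonyl sulfur. Among the measured compounds shown here, with no step touching that ring, nothing beyond the scatter is expected. Compound 3 is therefore expected to give about 4500 nM, with a likely range from 1500 nM to 13000 nM. The expected step of a 1.1-fold higher number from compound 2 to compound 3 (0.03 log units; within the scatter) sits within the scatter.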

Compound 3, half-maximal inhibitory concentration: 5860 nM
Estimate against measurement, compound 3: 1.3-fold (0.11 log units) below; measured number inside the range.
By their numbers in this assay, from the lowest: compounds 2, 3 and 1 (each within the scatter of the next, the first and the last beyond it).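

Changing the ring on the sulfonyl sulfur, 3,4-dimethylphenyl in place of 3-chlorophenyl, gives a 1.4-fold higher number from compound 2 to compound 3 (0.15 log units; within the scatter) in this assay. Within the data shown here, this is the first look at this position, and these two rings cannot be told apart here, even though one carries chlorine and the other carbon only. Nothing available explains this result. Going by these compounds, whether this position accepts only carbon-ring groups remains open. A ring bearing an amine or a carboxylic acid, or a plain methyl on the sulfonyl sulfur, could give a quite different number.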